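Compound 2 to compound 3: chloro for fluoro

The source may report more compounds than this note shows. Statements on the series, on what has been measured and on what is new or still open speak of the compounds shown alone.

Of the compounds shown here, two have been measured so far. In a functional assay on KYSE-450 cells (Homo sapiens) for inhibition, read by MTT assay, with a stated time of 48 h (a higher number here means a weaker inhibitor, a lower number a stronger inhibitor), compound 1 `COc1ccc(CNc2cc(OC)c(OC)c(OC)c2)cc1Cl` gives 47800 nM and compound 2 `C/C=C/C(=O)N(Cc1ccc(OC)c(F)c1)c1cc(OC)c(OC)c(OC)c1` gives 1400 nM as its number. Compound 2 therefore holds the lower of the two numbers, and its gap to compound 1 lies beyond the usual scatter. These two compounds differ in more than one place, so the gap cannot be assigned to any single change.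

Compound 3 `C/C=C/C(=O)N(Cc1ccc(OC)c(Cl)c1)c1cc(OC)c(OC)c(OC)c1` differs from compound 2 by one exchange, chloro in place of fluoro on an aromatic carbon. The place is ortho to a methoxy group and meta to a large group. Within the data shown here, no measured pair shows this exchange alone, so the data do not fix the size of the step. The anchor for the expectation is compound 2 at 1400 nM in this assay and no step beyond the scatter is expected in either direction. The step expected here is small (a 1.1-fold lower number from compound 2 to compound 3 (0.03 log units; within the scatter)). For compound 3 the estimated value is 1300 nM with an expected range from 500 nM to 3300 nM in this series.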

Compound 3, half-maximal inhibitory concentration: 10100 nM
Compound 3: the middle estimate sits 7.8-fold (0.89 log units) below what was measured, and the stated range ends below it.
By their numbers in this assay, from the lowest: compound 2; then compound 3; then compound 1.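

In this assay this aromatic carbon, ortho to a methoxy group and meta to a large group, does not treat the two halogens alike: going from 3-fluoro-4-methoxyphenyl to 3-chloro-4-methoxyphenyl gives a 7.2-fold higher number from compound 2 to compound 3 (0.86 log units; beyond the scatter) and so gives the series its first single-exchange reading at this position. With the chloro held fixed, (prop-1-en-1-yl)carbonyl in place of hydrogen on the nitrogen gives a 4.7-fold lower number from compound 1 to compound 3 (0.68 log units; beyond the scatter) and shows that this nitrogen substituent also changes the number, in the opposite direction to the halogen exchange. No measurement at hand accounts for either step.

The compounds shown leave open how a hydrogen, a methyl or a bromo on this carbon would compare with fluoro and chloro. They also leave open whether the chloro for fluoro step keeps its size and direction with a plain hydrogen on the nitrogen, as in compound 1, or with an acetyl group there.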